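The source may report more compounds than this note shows. Statements on the series, on what has been measured and on what is new or still open speak of the compounds shown alone.

Working notes on the series. In an assay on isolated protein for agonist activity at Bile acid receptor (Homo sapiens), read by AlphaScreen, with a stated time of 30 min (on this read-out lower numbers stand for smaller maximal responses and higher numbers for larger maximal responses), compound 1 `Cc1ccccc1-n1nc(C)c2c1NC(=O)[C@H](C)S[C@@H]2c1ccc(-c2ccccc2)cc1` gives 24%, the lowest of the three numbers seen so far. Going by the values given here, compound 2 `Cc1nn(-c2ccccc2C(C)C)c2c1[C@@H](c1ccc(Oc3ccccc3)cc1)S[C@@H](C)C(=O)N2` gives 174% and compound 3 `Cc1nn(-c2ccccc2I)c2c1C(c1ccc(Oc3ccccc3)cc1)SC(C)C(=O)N2` gives 130%; both stand beyond the scatter from compound 1, but no single-change step between measured compounds is available, so these pairs are read only by what their two values show. Compound 4 `COc1cccc(Oc2ccc([C@H]3S[C@@H](C)C(=O)Nc4c3c(C)nn4-c3ccccc3C)cc2)c1` is not yet measured. Against compound 1 it carries 3-methoxyphenoxy in place of phenyl on an aromatic carbon. Because compound 2 gives 174% and compound 3 gives 130%, an upward step in this assay, clearly beyond the scatter, is expected for compound 4. The estimate for compound 4 is 110%, within 50% to 170%, which is expected to amount to a number 86 percentage points higher from compound 1 to compound 4 (beyond the scatter).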

Compound 4, largest response reached (reported as efficacy), in percent of the reference or control that the assay uses: 120%
For compound 4 the middle estimate is 10 percentage points below the measured one, and the stated range covers the measured number.
By their numbers in this assay, from the lowest: compound 1; then compounds 4 and 3 (each within the scatter of the next); then compound 2.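

In this assay, 3-methoxyphenoxy in place of phenyl, on an aromatic carbon para to a large group, gives a number 96 percentage points higher from compound 1 to compound 4 (beyond the scatter). Going by these compounds alone, this is the first single-change reading, and it ties the swap at this position to a large rise in maximal response on the core of compound 1. Nothing at hand explains the rise.

The change brings in both a linking oxygen and a methoxy, and the rise cannot yet be assigned to either one. As far as these compounds go, how an amine or a carboxylic acid in place of the methoxy would read also stays open.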